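Chloro in place of hydrogen: expectation for compound 4

The source may report more compounds than this note shows. Statements on the series, on what has been measured and on what is new or still open speak of the compounds shown alone.

Measured so far in an assay on Sf9 cells for inhibition of protein deacetylase HDAC6 (Homo sapiens), read by fluorescence, with a stated time of 40 min, tested at 100 nM; a lower number here means less inhibition, a higher number more inhibition at the concentration tested (going by the name of the read-out):
compound 1 `O=C(NO)c1ccc(NCc2nc(-c3ccco3)nn2-c2ccccc2)cc1` gives 59.9%
compound 2 `Cc1ccc(-c2nc(CNc3ccc(C(=O)NO)cc3)n(-c3ccccc3)n2)s1` gives 79.7%
compound 3 `O=C(NO)c1ccc(NCc2nc(-c3ccccc3)nn2-c2ccccc2)cc1` gives 72.6%

Compound 3 stands second highest of the three numbers in this assay. Its nearest neighbour is compound 2, with a step of a number 7.1 percentage points lower from compound 2 to compound 3 (within the scatter) that lies within the scatter, so the two cannot be ordered. Its furthest is compound 1, with a step of a number 12.7 percentage points higher from compound 1 to compound 3 (beyond the scatter). The remaining measured step, a number 19.8 percentage points higher from compound 1 to compound 2 (beyond the scatter), likewise exchanges the group on an aromatic carbon of the shared core, as does the step from compound 1 to compound 3.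

Compound 4 `O=C(NO)c1ccc(NCc2nc(-c3ccccc3)nn2-c2ccccc2Cl)cc1` differs from compound 3 at a different position of the shared core: chloro in place of hydrogen on an aromatic carbon. None of the three measured steps touches this place; every one of them replaces furan-2-yl, 5-methylthiophen-2-yl or phenyl on an aromatic carbon, whereas here the change reads phenyl to 2-chlorophenyl. For the measured compounds named here, no measured step therefore bears on it, and neither a direction nor a size can be read from the series. The expected step of a number 2.6 percentage points lower from compound 3 to compound 4 (within the scatter) is none beyond the scatter, and the uncertainty is set wide. Compound 4 is accordingly expected at 70%, with a range from 50% to 88%.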

Compound 4, a percentage reported as inhibition, at one concentration (the size of the read-out at that concentration, not a potency): 64.6%
For compound 4 the middle estimate is 5.4 percentage points above the measured one; low and high end bracket the measured number.
By their numbers in this assay, from the lowest: compounds 1, 4, 3 and 2 (each within the scatter of the next, the first and the last beyond it).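

Working notes on the second place on the shared core: in this assay, chloro in place of hydrogen on an aromatic carbon, ortho to a large group, gives a number 8 percentage points lower from compound 3 to compound 4 (within the scatter), so the two numbers cannot be ordered. For the compounds shown here, this is the first reading at a place other than the one carrying furan-2-yl, 5-methylthiophen-2-yl or phenyl, and it shows that the change from phenyl to 2-chlorophenyl, a single added chlorine atom, produces no step that can be read beyond the scatter at the concentration tested. No measurement at hand accounts for the number obtained with this group, and none of the data speak to the reason for it.

The compounds shown leave open whether a group other than chloro at this place, such as methoxy, an amine or a carboxylic acid, would also stay within the scatter of the parent hydrogen compound. Also open, from the compounds shown here alone, is whether chloro at this place would give a similar reading alongside furan-2-yl or 5-methylthiophen-2-yl at the other place, since only the phenyl partner appears here.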